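The source may report more compounds than this note shows. Statements on the series, on what has been measured and on what is new or still open speak of the compounds shown alone.

Of the compounds shown here, three sharing one core have been measured in a functional assay on P388 cells (Mus musculus) for cytotoxicity, read by MTT assay, with a stated time of 72 h; a higher number here means a weaker inhibitor, a lower number a stronger inhibitor. Compound 1 `Cc1c(/N=C/c2ccc(N(C)C)cc2)c(=O)n(-c2ccccc2)n1C` gives 468000000 nM in this assay. Compound 2 `COc1ccc(/C=N/c2c(C)n(C)n(-c3ccccc3)c2=O)cc1` gives 186000000 nM in this assay, and a 2.5-fold lower number from compound 1 to compound 2 (0.40 log units; beyond the scatter) accompanies methoxy in place of dimethylamino on an aromatic carbon. Compound 3 `Cc1c(/N=C/c2ccccc2Cl)c(=O)n(-c2ccccc2)n1C` gives 324000000 nM in this assay, and a 1.7-fold higher number from compound 2 to compound 3 (0.24 log units; within the scatter) accompanies 2-chlorophenyl in place of 4-methoxyphenyl on a carbon with a double bond to nitrogen. On the numbers shown, compound 3 sits between compound 1 and compound 2, and both gaps lie within the usual scatter, so the three cannot be told apart with confidence.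

Compound 4 `COc1ccccc1/C=N/c1c(C)n(C)n(-c2ccccc2)c1=O` differs from compound 3 by methoxy in place of chloro on an aromatic carbon. For the measured compounds named here, only one measured step bears on this change: the step from compound 2 to compound 3 swapped the same two groups, chloro and methoxy, while also moving them to a different place on the ring, and it stayed within the scatter. The step from compound 1 to compound 2 concerns a different pair of groups. Going by the values given here, no measured step swaps chloro for methoxy at one fixed place, so the expectation rests on the small size of the step involving compound 3. In this assay compound 4 is therefore expected to show a 1.2-fold lower number from compound 3 to compound 4 (0.10 log units; within the scatter), a change not beyond the scatter. The estimate for compound 4 in this assay is 260000000 nM, with a range from 120000000 nM to 560000000 nM.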

Compound 4, half-maximal inhibitory concentration: 229000000 nM
Beside the measured number, compound 4's estimate is 1.1-fold (0.06 log units) above it; measured number inside the range.
By their numbers in this assay, from the lowest: compounds 2, 4, 3 and 1 (each within the scatter of the next, the first and the last beyond it).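

For the compounds shown here, this is the first direct swap at one fixed place on the ring, an aromatic carbon ortho to a large group: with methoxy in place of chloro, this assay shows a 1.4-fold lower number from compound 3 to compound 4 (0.15 log units; within the scatter), so at this place the two groups cannot be told apart. Going by these compounds alone, compound 4 also allows the first comparison of the methoxy group at two places on the ring, and a 1.2-fold higher number from compound 2 to compound 4 (0.09 log units; within the scatter), which means that moving it leaves no change that can be separated from ordinary assay variation. Among the steps now available, the only one beyond the scatter remains a 2.5-fold lower number from compound 1 to compound 2 (0.40 log units; beyond the scatter), and nothing shown offers an explanation for how closely compounds 2, 3 and 4 agree.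

On these data alone, it remains open whether a group of a different kind on this same aromatic carbon, such as a carboxylic acid or an amine, would give a step beyond the scatter. Within the data shown here, also open is how a longer chain in place of the methoxy group would read in this assay, since the groups compared at this place so far are just chloro and methoxy.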